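This account rests on a few compounds, and the source may have more. Where it says the series, first, only, none or still open, it means among the compounds named here.

Of the compounds shown here, three built on a shared core have been tested in a functional assay on HL-60 cells (Homo sapiens) for cytotoxicity, read by WST assay, with a stated time of 48 h; on this read-out higher numbers stand for an effect only at larger amounts of compound and lower numbers for an effect already at smaller amounts. Compound 1 (`O=C1OC[C@H](Cc2ccccc2)[C@H]1Cc1cccc(F)c1`) gives 75000 nM, and compound 2 (`COc1cc(C[C@H]2C(=O)OC[C@@H]2Cc2ccccc2)ccc1O`) gives 93000 nM. Compound 3 (`COc1ccccc1C[C@H]1COC(=O)[C@@H]1Cc1ccc(Cl)c(Cl)c1`) gives 14000 nM, the lowest of the three numbers, and its gaps to both compound 1 and compound 2 lie beyond the scatter of repeated measurements. No two of these compounds differ in one place only, so the data show no isolated effect of any single change.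

The next compound, compound 4 (`Cc1ccccc1C[C@H]1COC(=O)[C@@H]1Cc1ccc(Cl)c(Cl)c1`), differs from compound 3 in one place, with methyl in place of methoxy on an aromatic carbon, ortho to a large group (methyl in place of methoxy on an aromatic carbon). Among the measured compounds shown here, no measured step of this kind is available as a guide. The expectation in this assay is therefore of no step beyond the scatter, in either direction, which would leave compound 4 close to compound 3 at 14000 nM. Expressed as a step, the expected change is a 1.1-fold higher number from compound 3 to compound 4 (0.03 log units; within the scatter). For compound 4 the estimated value is 15000 nM, with an expected range from 6000 nM to 40000 nM.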

Compound 4, half-maximal effective concentration: 22000 nM
The estimate for compound 4 lay 1.5-fold (0.17 log units) below the measured number; the measured number falls inside the stated range.
By their numbers in this assay, from the lowest: compounds 3 and 4 (each within the scatter of the next); then compounds 1 and 2 (each within the scatter of the next).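

In this assay, among the compounds shown here, the first comparison in one place shows a 1.6-fold higher number from compound 3 to compound 4 (0.20 log units; within the scatter) when methyl replaces methoxy on an aromatic carbon, ortho to a large group. At this position, then, the loss of one heavy atom and one hydrogen-bond acceptor from the group leaves a difference that this read-out cannot separate from the scatter, at least with the rest of the structure held as it is in this pair. Nothing available bears on the reason for this result.

The compounds shown leave open whether other groups at the same position, such as an amine, a hydroxyl or a carboxylic acid, would also stay within the scatter of compound 3 or would move beyond it. For the compounds shown here, they also leave open whether methyl in place of methoxy would give a similar step with other groups elsewhere on the shared core, since this single pair is the only one in which the change can be read.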